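The source may report more compounds than this note shows. Statements on the series, on what has been measured and on what is new or still open speak of the compounds shown alone.

Among the compounds with values here, compound 3 `COc1ccc(OC)c(S(=O)(=O)Nc2cccc(N3C[C@@H](c4ccc(OC)c(OC5CCCC5)c4)CC3=O)c2)c1` is the only one of three measured compounds for which a functional assay on HEK293 cells (Homo sapiens) for cytotoxicity (a lower number here means that less compound is tolerated, a higher number that more compound is tolerated), reports a number, 7590 nM. Compound 1 `COc1ccc([C@H]2CC(=O)N(c3ccccc3)C2)cc1OC1CCCC1` gives in this assay only a limit, > 10000 nM. Compound 2 `COc1ccc([C@H]2CC(=O)N(c3cccc(NC(=O)C(C)=O)c3)C2)cc1OC1CCCC1` likewise gives only a limit, > 10000 nM. The step that the two limits leave unreadable from compound 1 to compound 2 is therefore unreadable, since both ends sit at the limit of > 10000 nM in this assay, at which 2 of the 3 values shown sit. Compound 4 `COc1ccc([C@H]2CC(=O)N(c3cccc(NS(=O)(=O)c4cccc(Br)c4)c3)C2)cc1OC1CCCC1` differs from compound 3 in one place: 3-bromophenyl in place of 2,5-dimethoxyphenyl on a sulfonyl sulfur. Within the data shown here, no measured step bears on this kind of change, so no shift beyond the usual scatter is expected. Compound 4 is therefore expected to show a step of a 1.2-fold higher number from compound 3 to compound 4 (0.07 log units; within the scatter) that stays within that scatter. The estimate for compound 4 is 9000 nM, with a range from 4000 nM to 20000 nM, and a fair chance that only a limit is reported.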

Compound 4, half-maximal cytotoxic concentration: > 10000 nM
Compound 4 gave a limit, no number; the forecaster's own chance of this, stated with the estimate: 50%; middle value at least 1.1-fold (0.04 log units) from the limit.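

Within the data shown here, putting 3-bromophenyl in place of 2,5-dimethoxyphenyl on the sulfonyl sulfur gives an at least 1.3-fold higher number from compound 3 to compound 4 (0.11 log units; that floor lies within the scatter) in this assay, the only readable step so far. Its floor lies within the scatter, so no shift beyond the scatter is shown, although the true step may be larger. The steps to compound 4 from compound 1 and compound 2 cannot be read, since all three compounds share one limit: the limit of > 10000 nM in this assay, at which 3 of the 4 values shown sit.

As far as these compounds go, it remains open whether a single methoxy group on that phenyl ring would give a number in this measurement. An amine or a carboxylic acid in place of the bromine also remains untested among the compounds shown.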